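Azetidine in place of pyrazine on the shared core

A few compounds are considered here, and "the series" means these few. Any claim that something is new, unique, unknown or untested is made for them only; others in the source may bear on it.

Compound 2 `COc1ccc(CNC(=O)c2cc(-c3cncc(C)c3)ncc2-c2cnccn2)nc1OC` gives 109 nM in an assay on CHO cells for antagonist activity at Orexin receptor type 2 (Homo sapiens), read by FLIPR, with a stated time of 5 min (on this read-out higher numbers stand for weaker inhibition and lower numbers for stronger inhibition), the highest of the three numbers shown. Compound 1 `COc1ccc(CNC(=O)c2cc(-c3cncc(C)c3)ncc2-c2cncc(F)c2)nc1OC` gives 57 nM, and the step of a 1.9-fold higher number from compound 1 to compound 2 (0.28 log units; within the scatter) lies within the scatter. Going by the values given here, compound 3 `COc1ccc(CNC(=O)c2cc(-c3cncc(C)c3)ccc2-c2ccccc2)nc1OC` gives 14 nM, a gap to compound 2 beyond the scatter, but the two differ in more than one place, so no single step can be drawn from them. Compound 4 `COc1ccc(CNC(=O)c2cc(-c3cncc(C)c3)ncc2N2CCC2)nc1OC` changes compound 2 thus: azetidin-1-yl in place of pyrazin-2-yl on an aromatic carbon. Among the compounds with values here, no measured step trades an aromatic ring for a non-aromatic one, and the only step that bears on this position, a 1.9-fold higher number from compound 1 to compound 2 (0.28 log units; within the scatter), exchanged one six-membered aromatic ring for another. With nothing to anchor the change, a modest weakening is expected in this assay. For compound 4 the estimate is 250 nM, between 60 nM and 1000 nM. The expected step of a 2.3-fold higher number from compound 2 to compound 4 (0.36 log units; beyond the scatter) is therefore uncertain in size.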

Compound 4, half-maximal inhibitory concentration: 83 nM
Beside the measured number, compound 4's estimate is 3.0-fold (0.48 log units) above it; the measured number falls inside the stated range.
By their numbers in this assay, from the lowest: compound 3; then compounds 1, 4 and 2 (each within the scatter of the next).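

In this assay this position accepts a non-aromatic ring: azetidin-1-yl gives a 1.3-fold lower number from compound 2 to compound 4 (0.12 log units; within the scatter) against pyrazin-2-yl and a 1.5-fold higher number from compound 1 to compound 4 (0.16 log units; within the scatter) against 5-fluoropyridin-3-yl. Both steps lie within the scatter, so among compounds 1, 2 and 4 an aromatic ring on this carbon is not needed to keep the number in this range. No data on hand bear on the reason for this result. From the compounds shown here alone, whether a morpholine, a piperidine or an open-chain dimethylamino group on this carbon stays in the same range remains open.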